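The source may report more compounds than this note shows. Statements on the series, on what has been measured and on what is new or still open speak of the compounds shown alone.

In a functional assay on MCF7 cells (Homo sapiens) for cytotoxicity, read by MTT assay, with a stated time of 96 h (a lower number here means a stronger inhibitor, a higher number a weaker inhibitor), compound 1 (`COc1cc(C(=O)c2cn(-c3ccc(F)cc3)cc2-c2ccccc2Cl)cc(OC)c1OC`) gives 83 nM and compound 2 (`COc1cc(C(=O)c2cn(-c3ccc(F)cc3)cc2-c2cccc(N)c2)cc(OC)c1OC`) gives 53 nM. Within the data shown here, these are the only two numbers available, and they lie within the scatter of each other, so compound 2 cannot be separated from compound 1. Compound 3 (`COc1cc(C(=O)c2cn(-c3ccc(F)cc3)cc2-c2ccc(N)cc2)cc(OC)c1OC`) has the same atoms as compound 2, joined differently: 4-aminophenyl in place of 3-aminophenyl on an aromatic carbon. The change is 4-aminophenyl in place of 3-aminophenyl, on an aromatic carbon of a five-membered aromatic ring with 1 nitrogen. Among the measured compounds shown here, only one measured step bears on it, a 1.6-fold lower number from compound 1 to compound 2 (0.19 log units; within the scatter), which puts 3-aminophenyl in place of 2-chlorophenyl at this same carbon and stays within the scatter. For the measured compounds named here, no measured compound carries 4-aminophenyl, so the data give no direction for this move. No step beyond the scatter is therefore expected in this assay. The expected outcome is a 1.1-fold lower number from compound 2 to compound 3 (0.03 log units; within the scatter). For compound 3 the estimated value is 50 nM, with an expected range of 17 nM to 150 nM.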

Compound 3, half-maximal inhibitory concentration: 12 nM
Compound 3: middle estimate off by 4.2-fold (0.62 log units), on the high side, and the stated range ends above it.
By their numbers in this assay, from the lowest: compound 3; then compounds 2 and 1 (each within the scatter of the next).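

In this assay the place of the amino group on this phenyl ring matters: 4-aminophenyl in place of 3-aminophenyl gives a 4.4-fold lower number from compound 2 to compound 3 (0.65 log units; beyond the scatter), although the two groups match in heavy atoms and in hydrogen-bond donors and acceptors. The earlier pair showed no such response, as its step stayed within the scatter, whereas 4-aminophenyl in place of 2-chlorophenyl gives a 6.9-fold lower number from compound 1 to compound 3 (0.84 log units; beyond the scatter), so the group on this carbon of the five-membered aromatic ring can shift the number beyond the scatter, and compound 3 now has the lowest number of the three. Nothing available on these compounds accounts for the difference between the 4-aminophenyl and 3-aminophenyl groups.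

The compounds shown leave open whether the amine itself is needed at the 4-position of this phenyl ring, or whether a 4-hydroxyphenyl, 4-methoxyphenyl or 4-chlorophenyl group would give a similar number. They also leave open how a 4-(dimethylamino)phenyl group or a 4-acetamidophenyl group, each of which changes the amine itself, would compare with the 4-aminophenyl group of compound 3.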